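The source may hold more compounds than are shown below. What is called first, only, known or untested is meant among the compounds shown, and "the series" means these compounds.

Measured so far:
- compound 1 `Cc1cc(C(N)=O)nn1Cc1cc(Cl)ccc1OCc1ccccc1`; in an assay on CHO-K1 cells for displacement of a labelled ligand from prostaglandin E2 receptor EP1 subtype (Homo sapiens) (on this read-out higher numbers stand for weaker inhibition and lower numbers for stronger inhibition), compound 1 gives 126 nM.
- compound 2 `CNC(=O)c1cc(C)n(Cc2cc(Cl)ccc2OCc2ccccc2)n1`; in this assay compound 2 gives 100 nM.
- compound 3 `Cc1cc(NC(=O)C2CCCO2)nn1Cc1cc(Cl)ccc1OCc1ccccc1`; in this assay compound 3 gives 39.8 nM.

Compound 1 has the highest of the three numbers. Compound 2 sits nearest, with a 1.3-fold lower number from compound 1 to compound 2 (0.10 log units; within the scatter), so the two cannot be ordered. Compound 3 sits furthest, with a 3.2-fold lower number from compound 1 to compound 3 (0.50 log units; beyond the scatter), and the same group also gives a 2.5-fold lower number from compound 2 to compound 3 (0.40 log units; beyond the scatter).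

Compound 4 `Cc1cc(NC(=O)OCc2ccccn2)nn1Cc1cc(Cl)ccc1OCc1ccccc1` has not yet been measured in this assay. Against compound 1 the change is (((pyridin-2-yl)methoxy)carbonyl)amino in place of carbamoyl on an aromatic carbon.

Going by the values given here, the steps that bear on this are those from compound 1 and compound 2 to compound 3, where the carbamoyl or methylcarbamoyl group was replaced by a ((oxolan-2-yl)carbonyl)amino group on the same aromatic carbon and the number fell modestly, beyond the scatter in both cases. Among the compounds with values here, compound 4 carries a different and larger group at that carbon, with the pyridine ring and the extra oxygen that the counts show, and no measured pair covers those features. The expectation is therefore a modest step down of similar size, a 2.5-fold lower number from compound 1 to compound 4 (0.40 log units; beyond the scatter), with wide uncertainty.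

For compound 4 the estimate in this assay is 50 nM, within 18 nM to 160 nM.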

Compound 4, half-maximal inhibitory concentration: 79.4 nM
Beside the measured number, compound 4's estimate is 1.6-fold (0.20 log units) below it; the measured number falls inside the stated range.
By their numbers in this assay, from the lowest: compounds 3, 4, 2 and 1 (each within the scatter of the next, the first and the last beyond it).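

In this assay, the (((pyridin-2-yl)methoxy)carbonyl)amino group, with its 11 heavy atoms and six-membered aromatic ring, is accepted on this aromatic carbon of the five-membered ring without a step that can be read: a 1.6-fold lower number from compound 1 to compound 4 (0.20 log units; within the scatter) and a 1.3-fold lower number from compound 2 to compound 4 (0.10 log units; within the scatter) both lie within the scatter, so compound 4 cannot be ordered against either amide. Changing the group on the carbonyl carbon, with (pyridin-2-yl)methoxy in place of oxolan-2-yl, gives a 2.0-fold higher number from compound 3 to compound 4 (0.30 log units; within the scatter), also within the scatter, so compound 3 and compound 4 cannot be ordered either, although only compound 3 stands beyond the scatter from compound 1 and compound 2. Nothing available accounts for how little the number moves with this much larger group.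

Going by these compounds, it remains open how a free amine or a carboxylic acid on the same aromatic carbon would read out, since these would show whether the carbonyl-linked groups matter here at all. A phenyl ring in place of the pyridin-2-yl ring, or a longer chain before the ring, would show whether the ring nitrogen or the length of the link has any bearing on the number.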